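The source may hold more compounds than are shown below. What is called first, only, known or untested is meant among the compounds shown, and "the series" means these compounds.

Measured in a functional assay on KBVIN cells (Homo sapiens) for antiproliferative activity, read by sulforhodamine B assay, with a stated time of 3 days; on this read-out higher numbers stand for an effect only at larger amounts of compound and lower numbers for an effect already at smaller amounts:
- Compound 1 `CCCc1ccc(-c2cc(=O)c3c(o2)C(CC)(CC)C(=O)C(CC)=C3O)cc1`: 12.2 uM
- Compound 2 `CCC1=C(O)c2c(oc(-c3ccc(CBr)cc3)cc2=O)C(CC)(CC)C1=O`: 27.9 uM

Compound 2 has the higher of these two numbers, and the gap between them is a 2.3-fold higher number from compound 1 to compound 2 (0.36 log units; beyond the scatter). The next structure is compound 3 `CCC1=C(O)c2c(oc(-c3cccc(C)c3)cc2=O)C(CC)(CC)C1=O`, which has 3-methylphenyl in place of 4-(bromomethyl)phenyl on an aromatic carbon.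

Among the measured compounds shown here, only that one measured step bears on this change, and it is modest. In it, bromo takes the place of ethyl on a saturated chain carbon bound to an aromatic carbon. Compound 3 has no bromine, and neither does compound 1, which reads 12.2 uM. However, no measured compound carries 3-methylphenyl, so this is only a loose guide.

In this assay, a modest move to a lower number than that of compound 2 is therefore expected, no larger than about the measured step, though it may stay within the scatter. The expected change is a 1.7-fold lower number from compound 2 to compound 3 (0.24 log units; within the scatter). For compound 3 the estimated value is 16 uM, with an expected range from 7 uM to 35 uM.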

Compound 3, concentration for half-maximal effect: 3.69 uM
Compound 3: the middle estimate sits 4.3-fold (0.64 log units) above what was measured; the whole stated range lies above it.
By their numbers in this assay, from the lowest: compound 3; then compound 1; then compound 2.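

In this assay, among the compounds shown here, this position on the shared core turns out to respond more strongly than the one earlier step suggested: replacing 4-(bromomethyl)phenyl with 3-methylphenyl gives a 7.6-fold lower number from compound 2 to compound 3 (0.88 log units; beyond the scatter), a larger move than a 2.3-fold higher number from compound 1 to compound 2 (0.36 log units; beyond the scatter). Losing the bromine cannot be the whole story, since replacing the bromine-free 4-propylphenyl with 3-methylphenyl also gives a 3.3-fold lower number from compound 1 to compound 3 (0.52 log units; beyond the scatter), which leaves compound 3 with the lowest number of the three, beyond the scatter from both of the others. For the compounds shown here, both steps also change two things at once, as the group on the phenyl ring differs in both its length and its place on that ring, so the first look at a 3-substituted phenyl ring comes bundled with a shorter substituent.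

Compounds with plain phenyl or 4-methylphenyl at this position would be needed to separate the effect of the shorter group from that of its place on the ring, and a 3-ethylphenyl or 3-aminophenyl group would show how much change the 3-position tolerates. Nothing available gives a reason for these differences.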